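The compounds below may be only part of what the source reports. "The series", "measured", "known", "first", "only" and "open" are said of these compounds alone.

Compound 1 `Cc1cccc(NC(=O)CCSc2ccc3c(/C=C/c4ccccn4)n[nH]c3c2)c1`: > 10000 nM
Compound 2 `O=C(CCSc1ccc2c(/C=C/c3ccccn3)n[nH]c2c1)Nc1cccc(C(F)(F)F)c1`: 2300 nM
Compound 3 `Cc1ccc(NC(=O)CCSc2ccc3c(/C=C/c4ccccn4)n[nH]c3c2)cc1`: > 10000 nM

All three values come from an ADME assay on BaF3 cells (Mus musculus) for antiproliferative activity, read by CCK-8 assay, with a stated time of 72 h; a lower number here means a stronger inhibitor of growth, a higher number a weaker inhibitor of growth. For compound 1 the entry is a limit, not a number. For compound 3 the entry is also a limit. For the measured compounds named here, compound 2 therefore holds the only true number in the set, and it is clearly the better of the pairs that can be read: an at least 4.3-fold lower number from compound 1 to compound 2 (0.63 log units; beyond the scatter), and an at least 4.3-fold higher number from compound 2 to compound 3 (0.63 log units; beyond the scatter).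

Compound 4 `COc1ccc(NC(=O)CCSc2ccc3c(/C=C/c4ccccn4)n[nH]c3c2)cc1C(F)(F)F` keeps everything in compound 2 and adds one group, methoxy in place of hydrogen on an aromatic carbon, ortho to the trifluoromethyl group and para to a large group: methoxy in place of hydrogen on an aromatic carbon.

Neither measured step adds a methoxy, and both remove the trifluoromethyl that compound 4 keeps. Going by the values given here, they show only that groups on this ring can move the number, so a small weakening is expected, possibly within the scatter, with wide uncertainty.

The expected change is a 1.3-fold higher number from compound 2 to compound 4 (0.12 log units; within the scatter).

For compound 4 the estimated value is 3000 nM, with an expected range of 700 nM to 10000 nM.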

Compound 4, concentration for 50% growth inhibition: > 10000 nM
Compound 4 ended at the assay's limit (the forecaster's own chance of this, stated with the estimate: 25%); middle value at least 3.3-fold (0.52 log units) away from the limit.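

In this assay, methoxy in place of hydrogen on the aromatic carbon ortho to a trifluoromethyl group gives an at least 4.3-fold higher number from compound 2 to compound 4 (0.63 log units; beyond the scatter). The earlier steps shown here only swapped the trifluoromethyl for a methyl or changed the group on the amide nitrogen, whereas here the trifluoromethyl stays and this single added group is enough to remove the measurable activity of compound 2. Going by these compounds, compound 4 gives > 10000 nM, which is a limit and not a number, so the full size of this step stays unknown.

Steps between compounds that both sit at a limit cannot be read, and only compound 2 has a true number to compare against: the limit of > 10000 nM in this assay, at which 3 of the 4 values shown sit. Whether a fluorine, a hydroxyl or an amine on this same carbon would keep the value of compound 2 remains open.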